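The source may hold more compounds than are shown below. What is called first, only, known or untested is meant among the compounds shown, and "the series" means these compounds.

Compounds 1, 2 and 3 share one skeleton and differ only in the configuration drawn at their ring carbons. In an assay for inhibition of alpha-N-acetylgalactosaminidase (Gallus gallus), tested at 1000 uM (on this read-out higher numbers stand for more inhibition at the one concentration tested (going by the name of the read-out) and lower numbers for less inhibition), compound 1 `O=C(O)[C@H]1NC[C@H](O)[C@H](O)[C@@H]1O` gives 4.5%, compound 2 `O=C(O)[C@H]1NC[C@H](O)[C@@H](O)[C@H]1O` gives 31%, and compound 3 `O=C(O)[C@H]1NC[C@@H](O)[C@H](O)[C@@H]1O` gives 11%. Compound 3 thus stands second of the three in this assay, close to compound 1 and clearly beneath compound 2. Going by the values given here, the steps so far are all changes of configuration alone: a number 26.5 percentage points higher from compound 1 to compound 2 (beyond the scatter) because of the fact that compounds 1 and 2 differ only in the configuration as drawn, a number 6.5 percentage points higher from compound 1 to compound 3 (within the scatter) because of the fact that compounds 1 and 3 differ only in the configuration as drawn, and a number 20 percentage points lower from compound 2 to compound 3 (beyond the scatter) because of the fact that compounds 2 and 3 differ only in the configuration as drawn. Compound 4 `O=C(O)[C@@H]1NC[C@H](O)[C@@H](O)[C@@H]1O` is the next such change: the two compounds have the same atoms and bonds and differ only in configuration as drawn: 3 of 4 stereo elements differ; a stereocentre at a saturated ring carbon is drawn S in compound 3 and R in compound 4; a stereocentre at a saturated ring carbon is drawn R in compound 3 and S in compound 4; a stereocentre at a saturated ring carbon is drawn S in compound 3 and R in compound 4. Since the measured steps of this kind range from no change beyond the scatter to a modest shift in either direction, compound 4 is expected to move from compound 3 by a number 4 percentage points higher from compound 3 to compound 4 (within the scatter) in this assay, with the direction uncertain. Compound 4 is therefore estimated at 15%, between 0% and 40%.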

Compound 4, a percentage reported as inhibition, at one concentration (the size of the read-out at that concentration, not a potency): 3.4%
Beside the measured number, compound 4's estimate is 11.6 percentage points above it; measured number inside the range.
By their numbers in this assay, from the lowest: compounds 4, 1 and 3 (each within the scatter of the next); then compound 2.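

In this assay a change at three stereo elements gives a number 7.6 percentage points lower from compound 3 to compound 4 (within the scatter) and a change at two gives a number 1.1 percentage points lower from compound 1 to compound 4 (within the scatter) so compound 4 cannot be told apart from compound 3 or compound 1. A change at two stereo elements also gives a number 27.6 percentage points lower from compound 2 to compound 4 (beyond the scatter) so the count of altered centres does not track the size of the step, and compound 2 alone now stands clear of the other three. With atoms and bonds identical, that gap can be traced to configuration alone: the fact that compounds 2 and 4 differ only in the configuration as drawn.

The compounds shown give a single concentration each and no potency, which leaves open whether compound 2 would hold its place in a fuller measurement. Also open, as far as these compounds go, is how an amide or a methyl ester in place of the carboxylic acid would read on the shared core.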